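A few compounds are considered here, and "the series" means these few. Any claim that something is new, unique, unknown or untested is made for them only; others in the source may bear on it.

Going by the values given here, compound 2 `Cc1cc(C)c(-c2c(C)nn(C)c2C)cc1NC(=O)c1ccc(OCc2ccccn2)cc1` is the only compound here whose solubility is given as an actual number: in a physicochemical assay for solubility, at pH 7.4 (on this read-out lower numbers stand for lower solubility and higher numbers for higher solubility), compound 2 gives 35000 nM. Compound 1 `Cc1csc(-c2cc(NC(=O)c3ccc(OCc4ccccn4)cc3)c(C)cc2C)n1` is reported only as a limit of the assay, < 1000 nM. Between these two lies a single structural change, and an at least 35-fold higher number from compound 1 to compound 2 (1.54 log units; beyond the scatter), although the limit of < 1000 nM in this assay, at which 1 of the 2 values shown sits, leaves the true size of that step open. Compound 3 `Cc1cc(C)c(-c2ccc(N)cn2)cc1NC(=O)c1ccc(OCc2ccccn2)cc1` is the compound still to be measured; it carries 5-aminopyridin-2-yl in place of 1,3,5-trimethyl-1H-pyrazol-4-yl on an aromatic carbon. Among the compounds with values here, no measured step covers this particular exchange: the one step at hand concerns a different group on the same aromatic carbon, so it gives no direct guide to the direction of the new change. A step within the scatter is therefore expected, a 1.8-fold lower number from compound 2 to compound 3 (0.24 log units; within the scatter). Compound 3 is expected to show about 20000 nM, with a likely range from 5000 nM to 80000 nM.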

Compound 3, solubility: < 1000 nM
Compound 3: only a limit was reported (the forecaster's own chance of this, stated with the estimate: 15%); middle value at least 20-fold (1.30 log units) away from the limit.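

At this aromatic carbon, putting 5-aminopyridin-2-yl in place of 1,3,5-trimethyl-1H-pyrazol-4-yl gives a large step in this assay (an at least 35-fold lower number from compound 2 to compound 3 (1.54 log units; beyond the scatter)) even though the entering group carries a hydrogen-bond donor that the leaving group lacks. So a second group at this position, after 4-methyl-1,3-thiazol-2-yl, now stands far from compound 2, which remains the only compound of the three with an actual number. The step between compound 1 and compound 3 cannot be read, and the two cannot be ranked: the limit of < 1000 nM in this assay, at which 2 of the 3 values shown sit.

As far as these compounds go, whether the high number of compound 2 depends on the three methyl groups of its ring stays open, and an unsubstituted 1H-pyrazol-4-yl would speak to that. How a plain phenyl ring at the same carbon would compare is equally unknown.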